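The source may report more compounds than this note shows. Statements on the series, on what has been measured and on what is new or still open speak of the compounds shown alone.

Measured so far in a functional assay (Sus scrofa) with sulfonylurea receptors; K-ATP channels (Homo sapiens) as the target; a higher number here means that more compound is needed for the effect, a lower number that less compound is needed:
Compound 1, `CCCC(=O)Nc1c(C(O)(C(F)(F)F)C(F)(F)F)ccc2ccccc12`, gives 708 nM.
Compound 2, `C/C=C/C(=O)Nc1c(C(O)(C(F)(F)F)C(F)(F)F)ccc2ccccc12`, gives 49 nM.
Compound 3, `O=C(Nc1c(C(O)(C(F)(F)F)C(F)(F)F)ccc2ccccc12)c1ccco1`, gives 182 nM.

Compound 2 stands lowest of the three numbers. Compound 3 is nearest to it, the step being a 3.7-fold higher number from compound 2 to compound 3 (0.57 log units; beyond the scatter); compound 1 is furthest, the step being a 14-fold lower number from compound 1 to compound 2 (1.16 log units; beyond the scatter).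

Compound 4, `O=C(Nc1c(C(O)(C(F)(F)F)C(F)(F)F)ccc2ccccc12)c1cnco1`, is not yet measured. It differs from compound 2 in one place: 1,3-oxazol-5-yl in place of prop-1-en-1-yl on a carbonyl carbon

Among the measured compounds shown here, two measured steps bear on this. Replacing propyl on the carbonyl carbon by furan-2-yl, a five-membered aromatic ring, gave a 3.9-fold lower number from compound 1 to compound 3 (0.59 log units; beyond the scatter), while exchanging prop-1-en-1-yl for the same five-membered aromatic ring gave a 3.7-fold higher number from compound 2 to compound 3 (0.57 log units; beyond the scatter). For the measured compounds named here, compound 4 carries a different five-membered aromatic ring, 1,3-oxazol-5-yl, in that place; no measured pair compares two such rings directly, so the size of any gap between the two rings is unknown. The closest guide is compound 3, whose number stands above that of compound 2 by a modest step.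

A modest rise from compound 2 is therefore expected for compound 4, of about a 3.1-fold higher number from compound 2 to compound 4 (0.49 log units; beyond the scatter). The estimated value for compound 4 in this assay is 150 nM, with a range from 60 nM to 400 nM.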

Compound 4, half-maximal effective concentration: 302 nM
Compound 4: the middle estimate sits 2.0-fold (0.30 log units) below what was measured; the range from low to high includes it.
By their numbers in this assay, from the lowest: compound 2; then compounds 3 and 4 (each within the scatter of the next); then compound 1.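

In this assay, exchanging the ring on the carbonyl carbon gives no readable difference (a 1.7-fold higher number from compound 3 to compound 4 (0.22 log units; within the scatter)), so furan-2-yl and 1,3-oxazol-5-yl cannot be told apart here, although the latter carries 2 hetero atoms and 2 hydrogen-bond acceptors. Compound 4 also confirms with a second ring what compound 3 showed first: the prop-1-en-1-yl group keeps its place at the low end (a 6.2-fold higher number from compound 2 to compound 4 (0.79 log units; beyond the scatter)), while the propyl group remains at the high end (a 2.3-fold lower number from compound 1 to compound 4 (0.37 log units; beyond the scatter)), and neither of the two aromatic rings among these four compounds goes against this ordering. Nothing available explains why the two rings sit where they do relative to the two open-chain groups.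

Still open, going by these compounds, is whether any ring on the carbonyl carbon, such as a phenyl, pyridinyl or cyclopropyl group, can reach the number of compound 2 (49 nM) in this assay or whether that takes an open chain with a double bond. A longer alkenyl chain, or the same chain with the opposite double-bond geometry, would show how much of that low number belongs to the prop-1-en-1-yl group as such.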